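Dropping the methoxy group from a sulfonamide ester series

The compounds below may be only part of what the source reports. "The series", "measured", "known", "first", "only" and "open" are said of these compounds alone.

Measured so far:
compound 1, `CN(C)C(=O)c1cccc(S(=O)(=O)N2CSC[C@H]2C(=O)O[C@@H](Cc2c(Cl)c[n+]([O-])cc2Cl)c2ccc(OC(F)F)c(OCC3CC3)c2)c1`: 25.9 uL/min
compound 2, `COc1ccc(S(=O)(=O)N2CCCC[C@H]2C(=O)O[C@@H](Cc2c(Cl)c[n+]([O-])cc2Cl)c2ccc(OC(F)F)c(OCC3CC3)c2)cc1C(=O)N(C)C`: 33.2 uL/min

In an ADME assay on cells (Hepatocyte, Homo sapiens) for metabolic stability, read by LC-MS, with a stated time of 90 min, tested at 1 uM (on this read-out higher numbers stand for fast clearance and lower numbers for slow clearance), compound 1 gives 25.9 uL/min and compound 2 gives 33.2 uL/min. Compound 2 stands at one end of these two numbers, but compound 1 sits so close that the gap between them is within the usual scatter.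

Compound 3, `CN(C)C(=O)c1cccc(S(=O)(=O)N2CCCC[C@H]2C(=O)O[C@@H](Cc2c(Cl)c[n+]([O-])cc2Cl)c2ccc(OC(F)F)c(OCC3CC3)c2)c1`, has not been measured. Its change from compound 2 is hydrogen in place of methoxy on an aromatic carbon. Among the compounds with values here, no step between two measured compounds isolates this methoxy-to-hydrogen swap. Compound 1, which also lacks the methoxy but carries a different ring, gives 25.9 uL/min, close to compound 2. The step of a 1.1-fold lower number from compound 2 to compound 3 (0.06 log units; within the scatter) is therefore expected to be small, within the scatter, with no clear direction. Compound 3 is estimated at 29 uL/min, within 15 uL/min to 58 uL/min.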

Compound 3, intrinsic clearance in a liver preparation (reported as CLH), per the amount of preparation that the assay uses: 64.6 uL/min
Estimate against measurement, compound 3: 2.2-fold (0.35 log units) below; the whole stated range lies below it.
By their numbers in this assay, from the lowest: compounds 1, 2 and 3 (each within the scatter of the next, the first and the last beyond it).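

Within the data shown here, compound 2 to compound 3 is the first step that isolates hydrogen in place of methoxy on this aromatic carbon, ortho to a dimethylcarbamoyl group and para to a large group: in this assay it is a 1.9-fold higher number from compound 2 to compound 3 (0.29 log units; within the scatter). The two compounds therefore cannot be told apart on this read-out, so the methoxy group shows no clear effect here. No measurement available bears on why this result arises. Still open, on these data alone, is how other groups on this carbon, such as fluorine, an amine or a longer ethoxy chain, would read.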